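This account rests on a few compounds, and the source may have more. Where it says the series, first, only, none or still open, it means among the compounds named here.

Compound 1 `Cc1noc(COC[C@H]2CCCN(c3ccnc4sc(C(N)=O)c(N)c34)C2)n1`: 563 ng.h/mL; compound 2 `Cn1ccnc1COC[C@H]1CCCN(c2ccnc3sc(C(N)=O)c(N)c23)C1`: 45 ng.h/mL.

In an ADME assay on the whole organism (Rattus norvegicus, strain Fischer 344) for pharmacokinetics, with a stated time of 8 h, at a dose of 3 mg/kg by the oral route (on this read-out higher numbers stand for higher exposure at the dose given and lower numbers for lower exposure), compound 1 stands highest of the two numbers, compound 2 lying below it by a 13-fold lower number from compound 1 to compound 2 (1.10 log units; beyond the scatter). Compound 3 `Cc1cc(N2CCC[C@H](COCc3nc(C)no3)C2)c2c(N)c(C(N)=O)sc2n1` differs from compound 1 by methyl in place of hydrogen on an aromatic carbon. Among the compounds with values here, no measured step touches that position: the only step known, a 13-fold lower number from compound 1 to compound 2 (1.10 log units; beyond the scatter), changes the group on the saturated chain and does not bear on it. Compound 3 is therefore expected to show no step beyond the scatter, a 1.1-fold higher number from compound 1 to compound 3 (0.03 log units; within the scatter). Compound 3 is estimated at 600 ng.h/mL, between 200 ng.h/mL and 1800 ng.h/mL.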

Compound 3, area under the concentration-time curve: 722 ng.h/mL
Compound 3: the middle estimate sits 1.2-fold (0.08 log units) below what was measured; low and high end bracket the measured number.
By their numbers in this assay, from the lowest: compound 2; then compounds 1 and 3 (each within the scatter of the next).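

Methyl in place of hydrogen on the aromatic carbon next to the ring nitrogen leaves the exposure in this assay within the scatter (a 1.3-fold higher number from compound 1 to compound 3 (0.11 log units; within the scatter)). This position of the shared core therefore takes this small addition without a step that can be read, whereas the earlier step lay on the saturated chain. Nothing measured here explains this outcome. From the compounds shown here alone, whether an amine or a methoxy group on this carbon would also stay within the scatter remains open, as does whether methyl there would behave alike with the 1-methyl-1H-imidazol-2-yl group of compound 2.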